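A tert-Butyl Group Added to the Aniline Ring

The compounds below may be only part of what the source reports. "The series", "measured", "known", "first", "only" and "open" are said of these compounds alone.

Three compounds built on a shared core were examined in an assay on isolated protein for inhibition of CAAX prenyl protease 2 (Homo sapiens), with stated times of 60 s and 60 min; a lower number here means a stronger inhibitor, a higher number a weaker inhibitor. Compound 1 `N#Cc1ccc(NC(c2ccccc2)c2ccc3cccnc3c2O)cc1` and compound 2 `CCOC(=O)c1ccc(NC(c2ccc(F)cc2)c2ccc3cccnc3c2O)cc1` carry their own substitution patterns, but in this assay compound 1 gives "not determined" (no result reported) and compound 2 gives "not determined" (no result reported), so neither contributes a number. Compound 3 `Oc1c(C(Nc2ccccc2)c2ccccc2)ccc2ccccc12` is thus the only one with a result: in this assay compound 3 gives 4900 nM, and it stands alone on the scale, with no other number beside it for comparison.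

Compound 4 `CC(C)(C)c1ccc(NC(c2ccccc2)c2ccc3ccccc3c2O)cc1` differs from compound 3 in one place: tert-butyl in place of hydrogen on an aromatic carbon. For the measured compounds named here, no step between two measured compounds is available to show what such a change does in this assay, so any expectation rests on compound 3 alone together with the change itself. The expected step in this assay is small, a 1.6-fold lower number from compound 3 to compound 4 (0.21 log units; within the scatter), leaning slightly toward a lower number but not clearly beyond the usual scatter. Compound 4 is accordingly estimated at 3000 nM in this assay, with a range expected to run from 700 nM to 12000 nM.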

Compound 4, half-maximal inhibitory concentration: 5000 nM
For compound 4 the middle estimate is 1.7-fold (0.22 log units) below the measured one; measured number inside the range.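

Replacing hydrogen with tert-butyl on an aromatic carbon, para to a large group, gives a 1.0-fold higher number from compound 3 to compound 4 (0.01 log units; within the scatter) in this assay. For the compounds shown here, this is the first step between two measured compounds in the set, as compound 3 previously stood alone on the scale, and it shows that this position can carry tert-butyl with no change in the number beyond the usual scatter. The data give no information on why the number holds steady at this position.

A single substituent at a single position cannot show whether the position is indifferent to substitution in general, or whether tert-butyl is simply one group that happens to leave the number where it was. As far as these compounds go, it remains open whether an amine, a carboxylic acid or a longer chain such as n-hexyl on the same aromatic carbon would also stay within the scatter of compound 3 or would move the number clearly in either direction.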